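Swapping the halogenated ring on compound 1

The compounds below may be only part of what the source reports. "The series", "measured", "known", "first", "only" and "open" are said of these compounds alone.

Measured compounds:
- Compound 1, `CN(C(=O)NC(=O)c1ccc(Cl)cc1Cl)c1nc(C(F)(F)F)c(C(=O)N/N=C/c2ccc(C(F)(F)F)cc2)s1`: 12.4 ug/mL
- Compound 2, `CN(C(=O)NC(=O)c1ccc(Cl)cc1Cl)c1nc(C(F)(F)F)c(C(=O)N/N=C/c2ccccc2C(F)(F)F)s1`: 10.7 ug/mL

Both compounds were tested in a functional assay on HepG2 cells (Homo sapiens) for inhibition, read by MTT assay, with a stated time of 72 h; a lower number here means a stronger inhibitor, a higher number a weaker inhibitor. For the measured compounds named here, compound 1 gives 12.4 ug/mL and stands as the higher of the two numbers; its only neighbour is compound 2, and the step of a 1.2-fold lower number from compound 1 to compound 2 (0.06 log units; within the scatter) is too small to count as a real difference. That step changes the ring at the far end of the molecule, on the carbon with a double bond to nitrogen.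

Compound 3, `CN(C(=O)NC(=O)c1c(F)cccc1F)c1nc(C(F)(F)F)c(C(=O)N/N=C/c2ccc(C(F)(F)F)cc2)s1`, has not yet been measured. It differs from compound 1 at the opposite end: 2,6-difluorophenyl in place of 2,4-dichlorophenyl on a carbonyl carbon. Going by the values given here, no measured step touches this part of the molecule, so the only step available, a 1.2-fold lower number from compound 1 to compound 2 (0.06 log units; within the scatter), gives no direct guidance beyond showing that a ring swap elsewhere left the number essentially unchanged.

Without a step that bears on this change, compound 3 is expected to land close to compound 1, with the step of a 1.2-fold higher number from compound 1 to compound 3 (0.08 log units; within the scatter) treated as uncertain in direction. Compound 3 is therefore estimated at 15 ug/mL, within a range from 6 ug/mL to 40 ug/mL.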

Compound 3, half-maximal inhibitory concentration: 49.6 ug/mL
The estimate for compound 3 lay 3.3-fold (0.52 log units) below the measured number; measured number outside the range, above it.
By their numbers in this assay, from the lowest: compounds 2 and 1 (each within the scatter of the next); then compound 3.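

For the compounds shown here, until now the only measured change was at the ring on the carbon with a double bond to nitrogen, and it stayed within the scatter. The change at the other end, on the carbonyl carbon, does move the number in this assay: the step is a 4.0-fold higher number from compound 1 to compound 3 (0.60 log units; beyond the scatter), so 2,6-difluorophenyl gives a weaker inhibitor here than 2,4-dichlorophenyl, even though the two groups match in heavy atoms, hydrogen-bond donors, hydrogen-bond acceptors and net charge. No measurement of any property of these two groups is available to explain the shift.

The swap alters both the kind of halogen and the places it occupies on the ring, so these compounds cannot separate the two, and a 2,4-difluorophenyl or 2,6-dichlorophenyl group would be needed to do that. Also open, going by these compounds, are how a plain phenyl ring or a ring carrying a methoxy group or an amine would behave at this position, and whether the same swap would raise the number on compound 2, with its 2-(trifluoromethyl)phenyl ring at the far end.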